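Cyclohexyl in place of thiophenylethyl on the acylguanidine nitrogen

This account rests on a few compounds, and the source may have more. Where it says the series, first, only, none or still open, it means among the compounds named here.

The measured compounds and their values:
compound 1 `Cc1nc(N)sc1CCCN/C(N)=N/C(=O)N[C@H](C)c1ccccc1` gives 17.8 nM in an assay on membranes from Sf9 cells for displacement of a labelled ligand from histamine H2 receptor (Homo sapiens), read by scintillation counting, with a stated time of 60 min; on this read-out higher numbers stand for weaker inhibition and lower numbers for stronger inhibition
compound 2 `CCCCCCNC(=O)/N=C(\N)NCCCc1sc(N)nc1C` gives 28.8 nM in this assay
compound 3 `Cc1nc(N)sc1CCCN/C(N)=N/C(=O)NC(C)c1cccs1` gives 63.1 nM in this assay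

Compound 3 shows the highest of the three numbers in this assay. Its nearest neighbour is compound 2, and the step of a 2.2-fold higher number from compound 2 to compound 3 (0.34 log units; beyond the scatter) is beyond the scatter; the step of a 3.5-fold higher number from compound 1 to compound 3 (0.55 log units; beyond the scatter) is larger still. Compound 1 and compound 2, by contrast, differ only within the scatter, as the step of a 1.6-fold higher number from compound 1 to compound 2 (0.21 log units; within the scatter) shows.

Compound 4 `Cc1nc(N)sc1CCCN/C(N)=N/C(=O)NC1CCCCC1` is the unmeasured member. The change from compound 3 to compound 4 is cyclohexyl in place of 1-(thiophen-2-yl)ethyl on an amide-type nitrogen. Going by the values given here, two measured steps bear on it. The step of a 2.2-fold higher number from compound 2 to compound 3 (0.34 log units; beyond the scatter) shows that going from hexyl to the thiophenylethyl group raised the number modestly, and the step of a 1.6-fold higher number from compound 1 to compound 2 (0.21 log units; within the scatter) shows that a six-carbon chain and the phenylethyl group sit within the scatter of one another. Since cyclohexyl carries the same carbon count as hexyl and no ring hetero atom, compound 4 is expected to land near compound 2 rather than near compound 3, giving a modest lowering in this assay estimated as a 2.1-fold lower number from compound 3 to compound 4 (0.32 log units; beyond the scatter). The estimate for compound 4 in this assay is 30 nM, with a range from 10 nM to 90 nM.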

Compound 4, inhibition constant: 170 nM
Beside the measured number, compound 4's estimate is 5.7-fold (0.75 log units) below it, outside the stated range (above it).
By their numbers in this assay, from the lowest: compounds 1 and 2 (each within the scatter of the next); then compound 3; then compound 4.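

In this assay, going by these compounds alone, this position proves less forgiving than the earlier compounds suggested: hexyl and 1-phenylethyl had stayed within the scatter of each other, yet cyclohexyl on the same amide-type nitrogen makes compound 4 the weakest inhibitor of the four. The open chain and the carbon ring are not interchangeable here, as the step from hexyl to cyclohexyl shows (a 5.9-fold higher number from compound 2 to compound 4 (0.77 log units; beyond the scatter)). Both aromatic groups also give lower numbers than the non-aromatic ring, with the loss smaller against 1-(thiophen-2-yl)ethyl (a 2.7-fold higher number from compound 3 to compound 4 (0.43 log units; beyond the scatter)) and larger against 1-phenylethyl (a 9.6-fold higher number from compound 1 to compound 4 (0.98 log units; beyond the scatter)).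

On these data alone, it remains open whether cyclopentyl, cyclohexylmethyl or a plain phenyl on this nitrogen would fall with compound 4 or with compound 1 and compound 2. No measurement among those available explains why the cyclohexyl compound gives the highest number in this series.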